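Moving the oxolane attachment on a dichloroaryl core

The compounds below may be only part of what the source reports. "The series", "measured", "known", "first", "only" and "open" are said of these compounds alone.

Three compounds have been measured in an ADME assay on microsomes from liver (Homo sapiens) for metabolic stability, read by LC-MS, using NADPH, with stated times of 10 min and 45 min, tested at 1 uM; on this read-out higher numbers stand for fast clearance and lower numbers for slow clearance:
Compound 1 `Cc1cc(C)c(CN2CCc3c(Cl)cc([C@H](CO)[C@H]4CCOC4)c(Cl)c3C2=O)c(=O)[nH]1` gives 21.3 uL/min.
Compound 2 `COc1cc(C)[nH]c(=O)c1CN1CCc2c(Cl)cc(-c3c(C)noc3C)c(Cl)c2C1=O` gives 70 uL/min.
Compound 3 `COC(c1cc(Cl)c2c(c1Cl)C(=O)N(Cc1c(C)cc(C)[nH]c1=O)CC2)C1CCN(C(=O)CO)CC1` gives 23 uL/min; 42 uL/min (2 entries).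

Compound 1 holds the lowest of the two single numbers; the nearest single number, that of compound 2, sits higher by a gap beyond the usual scatter. Compound 3 carries repeated entries, (the several entries of compound 3 in this assay, 23 uL/min; 42 uL/min (2 entries)), rather than one number, and these show how far repeats of this read-out can sit apart.

Compound 4 `Cc1cc(C)c(CN2CCc3c(Cl)cc([C@@H](CO)[C@H]4CCCO4)c(Cl)c3C2=O)c(=O)[nH]1` differs from compound 1 by a group of 8 heavy atoms (6 carbon, 2 oxygen; one five-membered non-aromatic ring with 1 hetero atom) in place of a group of 8 heavy atoms (6 carbon, 2 oxygen; one five-membered non-aromatic ring with 1 hetero atom), on an aromatic carbon. For the measured compounds named here, no measured pair shows a rearrangement of this kind, so nothing beyond the scatter is anticipated in this assay. Compound 4 is therefore expected to give 25 uL/min, with a range from 12 uL/min to 50 uL/min. The expected step is a 1.2-fold higher number from compound 1 to compound 4 (0.07 log units; within the scatter).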

Compound 4, intrinsic clearance in a liver preparation (reported as CLH), per the amount of preparation that the assay uses: 43 uL/min
Compound 4: the middle estimate sits 1.7-fold (0.24 log units) below what was measured, and the stated range covers the measured number.
By their numbers in this assay, from the lowest: compound 1; then compounds 4 and 2 (each within the scatter of the next).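

Rejoining the group on this aromatic carbon gives a 2.0-fold higher number from compound 1 to compound 4 (0.31 log units; beyond the scatter) in this assay even though no atom is gained or lost. This position therefore responds to how the five-membered non-aromatic ring is joined, not only to what the group contains. The step is modest, and repeats of this read-out can themselves sit well apart: the several entries of compound 3 in this assay, 23 uL/min; 42 uL/min (2 entries).

The compounds shown do not separate the effect of the ring's point of attachment from that of the stereocentres. From the compounds shown here alone, whether an amine in place of the ring oxygen would shift the number also remains open.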